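Pyrazolyl ring isomers in the imidazoline series

The compounds below may be only part of what the source reports. "The series", "measured", "known", "first", "only" and "open" are said of these compounds alone.

Measured so far in a functional assay with Alpha-1A adrenergic receptor (Homo sapiens) as the target, read by calcium flux; a higher number here means a larger maximal response, a lower number a smaller maximal response:
compound 1 `c1ccc(-c2cn[nH]c2)c(NCC2=NCCN2)c1`, 112%
compound 2 `Cn1ccc(-c2ccccc2NCC2=NCCN2)n1`, 116%

Compound 2 and compound 1 lie within the scatter of each other, as the step of a number 4 percentage points higher from compound 1 to compound 2 (within the scatter) shows. Compound 3 `Cn1nccc1-c1ccccc1NCC1=NCCN1` is not yet measured. It differs from compound 2 by 1-methyl-1H-pyrazol-5-yl in place of 1-methyl-1H-pyrazol-3-yl on an aromatic carbon. For the measured compounds named here, the only step known for this kind of pyrazolyl exchange is a number 4 percentage points higher from compound 1 to compound 2 (within the scatter), which did not leave the scatter, so no step beyond the scatter is expected in this assay. The estimate for compound 3 is 113%, with a range from 95% to 130%, meaning an expected step of a number 3 percentage points lower from compound 2 to compound 3 (within the scatter).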

Compound 3, largest response reached (reported as maximal response), in percent of the reference or control that the assay uses: 108%
Compound 3: the middle estimate sits 5 percentage points above what was measured, and the stated range covers the measured number.
By their numbers in this assay, from the lowest: compounds 3, 1 and 2 (each within the scatter of the next).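

Swapping 1-methyl-1H-pyrazol-3-yl for 1-methyl-1H-pyrazol-5-yl on this aromatic carbon, an exchange between two ring isomers with the same atoms, gives in this assay a number 8 percentage points lower from compound 2 to compound 3 (within the scatter). The step of a number 4 percentage points lower from compound 1 to compound 3 (within the scatter) shows the same for 1-methyl-1H-pyrazol-5-yl against 1H-pyrazol-4-yl, so all three pyrazolyl groups at this place now lie within the scatter of one another. Nothing available speaks to the origin of this result.

On these data alone, whether a carboxylic acid or a primary amine at this place would give a step beyond the scatter in this assay stays open.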